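The source may hold more compounds than are shown below. What is called first, only, known or untested is meant among the compounds shown, and "the series" means these compounds.

Compounds measured so far:
compound 1 `COc1cc2cc(Oc3ccc(NC(=O)Nc4cccc(C(F)(F)F)c4)cc3)c(C)nc2cc1OC` — 5920 nM
compound 2 `COc1cc2cc(Oc3ccc(NC(=O)Nc4ccc(Cl)c(C(F)(F)F)c4)cc3)c(C)nc2cc1OC` — 3850 nM

In a functional assay on KM12 cells (Homo sapiens) for inhibition, read by sulforhodamine B assay, with a stated time of 48 h (on this read-out higher numbers stand for weaker inhibition of growth and lower numbers for stronger inhibition of growth), compound 2 gives the lowest of the two numbers; the step of a 1.5-fold lower number from compound 1 to compound 2 (0.19 log units; within the scatter) lies within the scatter, so compound 1 and compound 2 cannot be told apart. Compound 3 `COc1cc2cc(Oc3ccc(NC(=O)Nc4ccc(Cl)c(Cl)c4)cc3)c(C)nc2cc1OC` is not yet measured. The change is chloro in place of trifluoromethyl on an aromatic carbon. No measured step swaps these two groups, so nothing recorded speaks directly to it; the only step shown, a 1.5-fold lower number from compound 1 to compound 2 (0.19 log units; within the scatter), was small. A step of a 1.3-fold higher number from compound 2 to compound 3 (0.11 log units; within the scatter) is therefore expected, of no clear direction beyond the scatter. Compound 3 is estimated at 5000 nM, between 2000 nM and 12500 nM.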

Compound 3, concentration for total growth inhibition: 13400 nM
The estimate for compound 3 lay 2.7-fold (0.43 log units) below the measured number, outside the stated range (above it).
By their numbers in this assay, from the lowest: compounds 2 and 1 (each within the scatter of the next); then compound 3.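

In this assay, chloro in place of trifluoromethyl is the first change shown that goes beyond the scatter (a 3.5-fold higher number from compound 2 to compound 3 (0.54 log units; beyond the scatter)), so this position, ortho to a chloro group, is sensitive to which group it carries. The 3,4-dichlorophenyl group also compares poorly with 3-(trifluoromethyl)phenyl (a 2.3-fold higher number from compound 1 to compound 3 (0.35 log units; beyond the scatter)). Nothing available explains either step. Still open, on these data alone, is how a methoxy group, a nitrile or an amine would fare at this position, and whether any group there could give a lower number than trifluoromethyl.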